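Enamine curcuminoids: isobutyl versus sec-butyl at the amine

The source may report more compounds than this note shows. Statements on the series, on what has been measured and on what is new or still open speak of the compounds shown alone.

Compound 1 `CC(C)CNC(=C\C(=O)/C=C/c1ccc(O)cc1)/C=C/c1ccc(O)cc1` and compound 3 `CCC(C)NC(=C\C(=O)/C=C/c1ccc(O)cc1)/C=C/c1ccc(O)cc1` share a core; compound 2 `COc1cc(/C=C/C(=O)/C=C(/C=C/c2ccc(OC(C)=O)c(OC)c2)NCC(C)C)ccc1OC(C)=O` and the unmeasured compound 4 `CCC(C)NC(=C\C(=O)/C=C/c1ccc(OC(C)=O)c(OC)c1)/C=C/c1ccc(OC(C)=O)c(OC)c1` share another. The difference between the two cores is not broken down here. In a functional assay for inhibition, read by spectrophotometry, with a stated time of 30 min, tested at 1 uM (a higher number here means more inhibition at the concentration tested (going by the name of the read-out), a lower number less inhibition), compound 1 gives 0.02%, compound 3 gives 0.03% and compound 2 gives 0%. The change sec-butyl in place of isobutyl on an amine nitrogen gives the step of a number 0 percentage points higher from compound 1 to compound 3 (within the scatter). The change sec-butyl in place of isobutyl on an amine nitrogen is the same change made on the core of compound 2. Since the measured step of this change lies within the scatter, and since compound 2 itself sits near the bottom of the read-out, the step from compound 2 to compound 4 is expected to be a number 0 percentage points higher from compound 2 to compound 4 (within the scatter). Compound 4 is therefore expected to give 0.02% in this assay, with a range from 0% to 8%.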

Compound 4, a percentage reported as inhibition, at one concentration (the size of the read-out at that concentration, not a potency): 0%
Beside the measured number, compound 4's estimate is 0 percentage points above it, within the range that was stated.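

In this assay, sec-butyl in place of isobutyl on an amine nitrogen gives no change at the digits printed from compound 2 to compound 4 (within the scatter), and the two cores agree on this change: the same change on two cores in this assay, a number 0 percentage points higher (within the scatter) from compound 1 to compound 3 and no change at the digits printed (within the scatter) from compound 2 to compound 4, 0 percentage points apart, within the scatter of two such steps. Within the data shown here, all four compounds read close to zero, so the agreement shows only that the change brings no measurable inhibition at the tested concentration on either core. It does not show that the change would carry over unaltered to a compound with measurable inhibition, as steps read this close to zero say nothing about the size of the change in such a compound.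

Still open, going by these compounds, is whether a longer chain, a benzyl group or a carboxylic acid on the amine nitrogen would lift the read-out on either core. Also open, on these data alone, is whether the two steps would still agree at a higher concentration.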